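The compounds below may be only part of what the source reports. "The series", "measured", "known", "first", "only" and "open" are said of these compounds alone.

Compound 1 `CCCN1C(N)=NC(N)=NC12CCN(C(=O)C1CC1)CC2`: in an ADME assay on HeLa cells (Homo sapiens) for cytotoxicity, read by microscopy, with a stated time of 6 days (on this read-out higher numbers stand for lower toxicity in this test and lower numbers for higher toxicity in this test), compound 1 gives > 100000 nM, a limit of the assay and not a number.
Compound 2 `COCCN1C(N)=NC(N)=NC12CCN(C(=O)C1CC1)CC2`: in this assay compound 2 gives > 100000 nM, again a limit.
Compound 3 `COCCN1C(N)=NC(N)=NC12CCN(C(=O)Nc1ccc(OC)cc1)CC2`: in this assay compound 3 gives > 100000 nM, again a limit.

Compound 2 stands where every measured compound stands, at the limit of > 100000 nM in this assay, at which 3 of the 3 values shown sit; only a limit is known for it, no number. The step from compound 1 to compound 2 is a step that the two limits leave unreadable from compound 1 to compound 2, and the step from compound 2 to compound 3 is a step that the two limits leave unreadable from compound 2 to compound 3, so neither can be read for size or direction. Compound 4 `CCS(=O)(=O)N1CCC2(CC1)N=C(N)N=C(N)N2CCOC` differs from compound 2 in one place: ethylsulfonyl in place of cyclopropylcarbonyl on an amine nitrogen in a ring. The two measured steps bear on compound 4 only in that both changes, one on a saturated chain carbon and one on a carbonyl carbon, left the value at the limit of > 100000 nM in this assay, at which 3 of the 3 values shown sit; neither gives a readable size. No step beyond the scatter is therefore expected in this assay from compound 2 to compound 4, and the expected step is a number no higher from compound 2 to compound 4 (the limit leaves the size open). Compound 4 is estimated at 100000 nM, with a range from 50000 nM to 300000 nM, and is expected to be reported once more as a limit.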

Compound 4, minimum cytotoxic concentration: > 100000 nM
Compound 4: a limit, no number (the forecaster's own chance of this, stated with the estimate: 85%); the middle value sits exactly at the limit.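

Compound 2 and compound 4 both sit at a limit in this assay and not at a number, so no step can be read between them. The compounds shown leave open at what concentration any of them becomes cytotoxic, and whether any change alters that concentration.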